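Hydroxamate series: methoxy in place of methyl

The source may report more compounds than this note shows. Statements on the series, on what has been measured and on what is new or still open speak of the compounds shown alone.

Measured so far:
- compound 1, `O=C(CCCSc1nc(O)cc(CCc2ccccc2)n1)NO`: in an assay on isolated protein for inhibition of histone deacetylase HD2 (Zea mays) (on this read-out lower numbers stand for stronger inhibition and higher numbers for weaker inhibition), compound 1 gives 205 nM
- compound 2, `CC(c1ccccc1)c1cc(O)nc(SCCCCCC(=O)NO)n1`: in this assay compound 2 gives 9 nM

Compound 2 holds the lowest number of the two; the number of compound 1 is higher, and that gap lies beyond the scatter. The two compounds differ in more than one place, so the two values are stated as they are and no single change is credited with the gap.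

Compound 3, `COC(c1ccccc1)c1cc(O)nc(SCCCCCC(=O)NO)n1`, is not yet measured. It differs from compound 2 by methoxy in place of methyl on a saturated chain carbon bound to two aromatic carbons. Within the data shown here, no measured pair covers this change, so the expected step of a 1.7-fold higher number from compound 2 to compound 3 (0.22 log units; within the scatter) is small, at most a little towards a higher number, and may well stay within the scatter. For compound 3 the estimate in this assay is 15 nM, with a range from 5 nM to 50 nM.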

Compound 3, half-maximal inhibitory concentration: 82 nM
Compound 3: middle estimate off by 5.5-fold (0.74 log units), on the low side; the whole stated range lies below it.
By their numbers in this assay, from the lowest: compound 2; then compound 3; then compound 1.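

On the saturated chain carbon bound to two aromatic carbons, the series does not tolerate every small exchange: in this assay, methoxy in place of methyl gives a 9.1-fold higher number from compound 2 to compound 3 (0.96 log units; beyond the scatter) and so moves the read-out towards weaker inhibition. Among these compounds, this pair is the first to differ in one place, so this position can now be tied to a change beyond the scatter, with one heavy atom and one hydrogen-bond acceptor added. Nothing measured here bears on why the step occurs.

Still open, going by these compounds, is whether the step follows the oxygen itself or the larger group, which an ethyl or a hydroxyl on the same carbon would help separate. A plain hydrogen there would show what the methyl of compound 2 contributes.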